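The source may report more compounds than this note shows. Statements on the series, on what has been measured and on what is new or still open speak of the compounds shown alone.

Compound 1 `COc1ccc(-c2cc(=O)c3c(OC)cc(OC)cc3n2S(=O)(=O)c2cc(F)c(F)c(F)c2)cc1`: in an ADME assay on BJ cells (Homo sapiens) for antiproliferative activity, with a stated time of 72 h (on this read-out higher numbers stand for an effect only at larger amounts of compound and lower numbers for an effect already at smaller amounts), compound 1 gives > 65500 nM, which is a limit of the assay, not a number.
Compound 2 `COc1ccc(-c2cc(=O)c3c(OC)cc(OC)cc3n2S(=O)(=O)c2ccc(Cl)cc2)cc1`: in this assay compound 2 gives > 34400 nM, again a limit of the assay.

Compound 2 thus stands at a limit in this assay, as told by the limit of > 34400 nM in this assay, at which 1 of the 2 values shown sits. The value of compound 1 is likewise a limit, (the limit of > 65500 nM in this assay, at which 1 of the 2 values shown sits). Among the compounds with values here, the only measured step, a step that the two limits leave unreadable from compound 1 to compound 2, is therefore unreadable in size and direction.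

Compound 3 `COc1ccc(-c2cc(=O)c3c(OC)cc(OC)cc3n2S(=O)(=O)c2cccc(Br)c2)cc1` carries 3-bromophenyl in place of 4-chlorophenyl on a sulfonyl sulfur. No readable measured step bears on this change. Compound 3 is expected to stay at a limit, so a step that the limit leaves unreadable from compound 2 to compound 3 is expected to be none beyond the scatter. The estimate for compound 3 in this assay is 60000 nM, in the range 20000 nM to 200000 nM.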

Compound 3, half-maximal effective concentration: > 58600 nM
Compound 3: a limit, no number (the forecaster's own chance of this, stated with the estimate: 85%); the middle value does not contradict the limit.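

In this assay compound 3 gives > 58600 nM, a limit of the assay, so its steps from compound 1 and compound 2 cannot be read. The compounds shown leave open whether any of these sulfonyl substituents gives a measurable effect in this assay.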